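Compound 2 to compound 3: notes on the series

The source may hold more compounds than are shown below. What is called first, only, known or untested is meant among the compounds shown, and "the series" means these compounds.

Compound 1 `CC(=O)Nc1ccc2ncc(-c3cnn(C)c3)cc2n1`: > 50000 nM
Compound 2 `Cn1cc(-c2cnc3ccc(NC(=O)c4cccnc4)nc3c2)cn1`: > 50000 nM

Both entries come from a functional assay on HeLa cells (Homo sapiens) for antiproliferative activity, read by MTT assay, with a stated time of 48 h (on this read-out higher numbers stand for weaker inhibition and lower numbers for stronger inhibition), and neither is a number. Compound 2 stands only at a limit, > 50000 nM. Compound 1 also stands only at a limit, > 50000 nM.

The next change leads to compound 3 `Cn1cc(-c2cnc3ccc(NCC4CC4)nc3c2)cn1`, with cyclopropylmethyl in place of (pyridin-3-yl)carbonyl on a nitrogen on an aromatic ring. Among the compounds with values here, the only measured step that bears on it is a step that the two limits leave unreadable from compound 1 to compound 2. That step changed the group on the carbonyl carbon, whereas here the whole (pyridin-3-yl)carbonyl leaves. The evidence so far amounts to the limit of > 50000 nM in this assay, at which 2 of the 2 values shown sit. No measured size carries over to this assay, and no firm direction can be read. Only a modest move towards stronger inhibition is expected, and a further limit remains likely. The expected step is an at least 1.2-fold lower number from compound 2 to compound 3 (0.09 log units; that floor lies within the scatter). For compound 3 the estimated value is 40000 nM, with an expected range of 10000 nM to 80000 nM.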

Compound 3, half-maximal inhibitory concentration: > 50000 nM
Compound 3: no number, only a limit (the forecaster's own chance of this, stated with the estimate: 65%); middle value at least 1.2-fold (0.09 log units) away from the limit.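

Compound 3 stands at > 50000 nM, a limit and not a number, so its steps from compound 1 and compound 2 cannot be read. The compounds shown leave open whether acetyl, (pyridin-3-yl)carbonyl and cyclopropylmethyl on the nitrogen differ at all in this assay.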